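Adding a methoxy to an inactive chlorobutanamide

The compounds below may be only part of what the source reports. "The series", "measured", "known", "first", "only" and "open" are said of these compounds alone.

Compound 1, `CCCCC(OC)c1cccc(NC(=O)NC(=O)CCl)c1`, gives 4200 nM in a functional assay on M21 cells (Homo sapiens) for antiproliferative activity, with a stated time of 48 h; a lower number here means a stronger inhibitor, a higher number a weaker inhibitor.
Compound 2, `CCCCC(OC)c1cccc(NC(=O)NC(=O)CC)c1`, reaches only the assay limit of > 100000 nM in this assay.
Compound 3, `CCCCCc1cccc(NC(=O)CCCCl)c1`, reaches only the assay limit of > 100000 nM in this assay.

Compound 3 stands at the limit; (the limit of > 100000 nM in this assay, at which 2 of the 3 values shown sit), so its value is not a number but a ceiling, and compound 3 shares that ceiling with one other compound. Compound 4, `CCCCC(OC)c1cccc(NC(=O)CCCCl)c1`, is not yet measured. It differs from compound 3 by methoxy in place of hydrogen on a saturated chain carbon bound to an aromatic carbon and a saturated chain carbon.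

Going by the values given here, only one measured step exists, and it does not touch this change: an at least 23-fold higher number from compound 1 to compound 2 (1.37 log units; beyond the scatter) concerns the group on the carbonyl side chain, whereas compound 4 keeps the chlorobutanoyl amide of compound 3 unchanged. Among the compounds with values here, no measured pair shows the effect of the methoxy on its own, since compounds 1 and 2 both carry it and differ from compound 3 in more than that one place. The step from compound 3 to compound 4 is therefore expected to stay within the scatter, as a number no higher from compound 3 to compound 4 (the limit leaves the size open).

Compound 4 is accordingly estimated at 100000 nM in this assay, most likely again reported only as a limit, with a range from 20000 nM to 300000 nM.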

Compound 4, half-maximal inhibitory concentration: > 100000 nM
Compound 4 gave a limit, no number (the forecaster's own chance of this, stated with the estimate: 70%); the middle value sits exactly at the limit.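

Compound 4 lands at the ceiling of this assay: the limit of > 100000 nM in this assay, at which 3 of the 4 values shown sit.

So putting methoxy in place of hydrogen on a saturated chain carbon bound to an aromatic carbon and a saturated chain carbon does not lift the inactive chlorobutanamide of compound 3 to a readable number, something the earlier compounds could not show, as none of them isolated this change. The same compound also shows that methoxy plus a chlorine on the side chain is not enough, since swapping the ((chloromethyl)carbonyl)amino group for 3-chloropropyl on the carbonyl carbon gives an at least 23-fold higher number from compound 1 to compound 4 (1.37 log units; beyond the scatter). Among the four compounds, only compound 1 gives a number, so activity here follows that particular side chain rather than the methoxy or the chlorine alone.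

The steps that link compound 4 to compound 2 and compound 3 cannot be read, as both ends are limits, so any smaller effect of the methoxy stays hidden beyond the ceiling. Still open, from the compounds shown here alone, is whether the side chain of compound 1 works without the methoxy, and whether a hydroxyl or an amine on that same carbon would behave any differently.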